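Swapping the aryl group on a triazole: a small change expected

This account rests on a few compounds, and the source may have more. Where it says the series, first, only, none or still open, it means among the compounds named here.

Compound 1, `CCCCCc1cn(C(c2ccccc2)c2cc3cc(Br)ccc3nc2OC)nn1`, gives 11.4% in an ADME assay on PC-3 cells (Homo sapiens) for cytotoxicity, read by sulforhodamine B assay, with a stated time of 48 h, tested at 10 uM; a higher number here means more inhibition at the concentration tested (going by the name of the read-out), a lower number less inhibition.
Compound 2, `COc1nc2ccc(Br)cc2cc1C(c1ccccc1)n1cc(-c2ccccc2C(F)(F)F)nn1`, gives 17.4% in this assay.

Both measured compounds inhibit only weakly at the concentration tested. Compound 2 gives 17.4% in this assay and compound 1 gives 11.4%, and these two numbers lie within the scatter of each other, so neither compound stands apart from the other. Among the measured compounds shown here, the one measured step, a number 6 percentage points higher from compound 1 to compound 2 (within the scatter), is within the scatter as well.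

Compound 3, `COc1nc2ccc(Br)cc2cc1C(c1ccccc1)n1cc(-c2cccc(F)c2)nn1`, has not yet been measured. Compared with compound 2 the change is 3-fluorophenyl in place of 2-(trifluoromethyl)phenyl on an aromatic carbon. For the measured compounds named here, the only step that bears on it, a number 6 percentage points higher from compound 1 to compound 2 (within the scatter), replaced a different group at the same position and produced no change beyond the scatter. Going by the values given here, no step here moved the read-out appreciably, so a number close to the two measured ones is expected.

Compound 3 is estimated to give 14%, with a range from 2% to 30%. This estimate corresponds to an expected step of a number 3.4 percentage points lower from compound 2 to compound 3 (within the scatter), a change that is expected to stay within the scatter.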

Compound 3, a percentage reported as inhibition, at one concentration (the size of the read-out at that concentration, not a potency): 14.6%
Compound 3: middle estimate off by 0.6 percentage points, on the low side; the measured number falls inside the stated range.
By their numbers in this assay, from the lowest: compounds 1, 3 and 2 (each within the scatter of the next).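

In this assay, 3-fluorophenyl in place of 2-(trifluoromethyl)phenyl gives a number 2.8 percentage points lower from compound 2 to compound 3 (within the scatter) and, set against the pentyl group, gives a number 3.2 percentage points higher from compound 1 to compound 3 (within the scatter) on the same aromatic carbon. This adds a second kind of change to the earlier one: a group of 7 heavy atoms replacing one with more heavy atoms, with the fluorine-bearing phenyl ring differently substituted, leaves the read-out as flat as the swap of a chain for a ring did. The measurements at hand offer no explanation for this flat picture.

Going by these compounds, whether an amine or a carboxylic acid on this aromatic carbon would move the number beyond the scatter remains open. So does whether any change to the shared core, rather than to this group, would do so.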